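This account rests on a few compounds, and the source may have more. Where it says the series, first, only, none or still open, it means among the compounds named here.

Measured so far in an ADME assay on BJ cells (Homo sapiens), read by MTT assay, with a stated time of 72 h; a lower number here means a stronger inhibitor, a higher number a weaker inhibitor:

Compound 1 `CNc1ncnc2c1c(-c1ccsc1)cn2[C@@H]1O[C@H](CO)[C@@H](O)[C@H]1O` — compound 1 gives > 100000 nM, which is a limit of the assay rather than a number.
Compound 2 `O=c1[nH]cnc2c1c(-c1cccs1)cn2[C@@H]1O[C@H](CO)[C@@H](O)[C@H]1O` — compound 2 gives > 100000 nM, again a limit of the assay.
Compound 3 `COc1ncnc2c1c(-c1ccsc1)cn2[C@@H]1O[C@H](CO)[C@@H](O)[C@H]1O` — compound 3 gives 64300 nM.

Compound 1 therefore stands only at a limit in this assay. Its value is one of the two that sit at the limit of > 100000 nM in this assay, at which 2 of the 3 values shown sit, so the shown numbers give a boundary for compound 1 and no more; they do not place it above or below compound 2, and the one step with a number, an at least 1.5-fold lower number from compound 1 to compound 3 (0.19 log units; that floor lies within the scatter), concerns a change at another place of the shared core and only sets a floor that lies within the scatter.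

Compound 4 `CNc1ncnc2c1c(-c1cc3ccccc3o1)cn2[C@@H]1O[C@H](CO)[C@@H](O)[C@H]1O` differs from compound 1 by 1-benzofuran-2-yl in place of thiophen-3-yl on an aromatic carbon. For the measured compounds named here, no measured step touches this change; the step from compound 1 to compound 3 and the limit of compound 2 offer nothing on the group that leaves or the group that enters. With nothing in the shown numbers pointing beyond the scatter in either direction, compound 4 is expected to stay close to where compound 1 stands, at 80000 nM, between 20000 nM and 200000 nM, which means an expected step of an at least 1.2-fold lower number from compound 1 to compound 4 (0.09 log units; that floor lies within the scatter), within the scatter, and a real chance that this assay once more reports only a limit for compound 4.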

Compound 4, half-maximal inhibitory concentration: 75600 nM
The estimate for compound 4 lay 1.1-fold (0.02 log units) above the measured number, and the stated range covers the measured number.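

At this position of the shared core, on an aromatic carbon two ring bonds from the ring nitrogen, this assay now gives an at least 1.3-fold lower number from compound 1 to compound 4 (0.12 log units; that floor lies within the scatter). The position therefore accepts 1-benzofuran-2-yl, which carries an additional six-membered aromatic ring of carbon only and has oxygen in place of sulfur in its five-membered ring, and the result still stays in the same high range of the assay, with no step beyond the scatter. Compound 1 remains at a limit of the assay, so this step is only a floor and the true distance between the two groups stays unknown: the limit of > 100000 nM in this assay, at which 2 of the 4 values shown sit.

The compounds shown leave open whether any group at this position would move the number clearly beyond the scatter, for instance a simple phenyl ring, an aminomethyl group or a carboxylic acid, since only thiophen-3-yl and 1-benzofuran-2-yl can be compared here. They also leave open whether the step from thiophen-3-yl to 1-benzofuran-2-yl would look the same with methoxy in place of methylamino on the shared core, where a number rather than a limit would be the starting point.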